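The compounds below may be only part of what the source reports. "The series", "measured", "known", "first", "only" and "open" are said of these compounds alone.

Compound 1, `NC(=O)c1c(NC(=O)c2ccc(C(F)(F)F)cc2)sc2c1CCN(Cc1c(Cl)cccc1Cl)C2`, gives in a functional assay on HeLa cells (Homo sapiens) for antiproliferative activity, with a stated time of 24 h (on this read-out lower numbers stand for stronger inhibition and higher numbers for weaker inhibition), only a limit, > 50000 nM.
Compound 2, `Cc1ccc(C(=O)Nc2sc3c(c2C(N)=O)CCN(Cc2c(Cl)cccc2Cl)C3)cc1`, gives in this assay 47400 nM.
Compound 3, `NC(=O)c1c(NC(=O)c2ccccc2F)sc2c1CCN(Cc1c(Cl)cccc1Cl)C2`, gives in this assay 33000 nM.

Compound 3 holds the lower of the two actual numbers, but the gap to compound 2, a 1.4-fold lower number from compound 2 to compound 3 (0.16 log units; within the scatter), lies within the scatter, so the two cannot be told apart. The value of compound 1 is a limit of the assay, not a number (the limit of > 50000 nM in this assay, at which 1 of the 3 values shown sits).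

Compound 4, `NC(=O)c1c(NC(=O)c2cccc([N+](=O)[O-])c2)sc2c1CCN(Cc1c(Cl)cccc1Cl)C2`, is not yet measured. It differs from compound 3 in one place: 3-nitrophenyl in place of 2-fluorophenyl on a carbonyl carbon. The two measured steps that touch the same place are the swap of the aryl group on the carbonyl carbon, an at least 1.5-fold lower number from compound 1 to compound 3 (0.18 log units; that floor lies within the scatter) and a 1.4-fold lower number from compound 2 to compound 3 (0.16 log units; within the scatter); both are small and within the scatter. With three different aryl groups giving no step beyond the scatter, another aryl swap at this position is expected to give none either.

Compound 4 is therefore expected to give about 36000 nM, within a range of 15000 nM to 90000 nM. The step this estimate implies is expected to be a 1.1-fold higher number from compound 3 to compound 4 (0.04 log units; within the scatter).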

Compound 4, half-maximal inhibitory concentration: 46100 nM
The estimate for compound 4 lay 1.3-fold (0.11 log units) below the measured number, and the stated range covers the measured number.
By their numbers in this assay, from the lowest: compounds 3, 4 and 2 (each within the scatter of the next). At a limit, above all of these: compound 1.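

The aryl group on the carbonyl carbon now carries a nitro group, which brings nitrogen, oxygen and hydrogen-bond acceptors that 2-fluorophenyl lacks, yet the swap gives only a 1.4-fold higher number from compound 3 to compound 4 (0.15 log units; within the scatter). The comparison with the 4-methylphenyl group reads the same, with a 1.0-fold lower number from compound 2 to compound 4 (0.01 log units; within the scatter), so this position has now taken a clearly different kind of substituent without any step beyond the scatter. Compound 1 sits at a limit rather than a number, so its step, an at least 1.0-fold lower number from compound 1 to compound 4 (0.03 log units; that floor lies within the scatter), gives only a floor: the limit of > 50000 nM in this assay, at which 1 of the 4 values shown sits.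

From the compounds shown here alone, all four compounds carry a substituted phenyl group here, so it remains open what a phenyl ring bearing an amine or a carboxylic acid, or a longer chain in place of the ring, would give. Going by these compounds, the rest of the shared core is also unchanged throughout, so its contribution remains open too.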